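The source may hold more compounds than are shown below. What is called first, only, known or untested is meant among the compounds shown, and "the series" means these compounds.

Measured compounds in an ADME assay on BJ cells (Homo sapiens) for cytotoxicity, with a stated time of 72 h; a lower number here means that less compound is needed, a higher number that more compound is needed for the effect
- Compound 1 `COc1cc2ncnc(-n3nc(-c4ccccn4)nc3N)c2cc1N` gives "not determined" (no result reported)
- Compound 2 `COc1cc2ncnc(-n3nc(-c4ccccn4)nc3N)c2cc1OCCCN(C)C` gives > 25000 nM as a limit
- Compound 3 `CCN(CC)C(=O)COc1cc2c(-n3nc(-c4ccccn4)nc3N)ncnc2cc1OC` gives > 25000 nM as a limit

Compound 3 stands at > 25000 nM in this assay and this is a limit, not a number. Compound 1 has no reported result and offers no comparison. The next compound is compound 4 `COc1cc2ncnc(-n3nc(-c4ccccn4)nc3N)c2cc1OCCNC(=O)OC(C)(C)C` and its change from compound 3 reads ((tert-butoxycarbonyl)amino)methyl in place of diethylcarbamoyl on a saturated chain carbon bound to an oxygen on an aromatic ring with ((tert-butoxycarbonyl)amino)methyl in place of diethylcarbamoyl on a saturated chain carbon bound to an oxygen on an aromatic ring. Going by the values given here, the one measured step at this place is a step that the two limits leave unreadable from compound 2 to compound 3 and it gives no size to carry over. Among the compounds with values here, no step beyond the scatter is expected in either direction, because the limit of > 25000 nM in this assay, at which 2 of the 3 values shown sit, is the only reading that compound 2 and compound 3 share. The expected step is a number no higher from compound 3 to compound 4 (the limit leaves the size open) and it remains an estimate. Compound 4 is expected near 25000 nM with an estimated range from 10000 nM to 40000 nM. Compound 4 may well yield only a limit, and this too is an expectation.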

Compound 4, half-maximal effective concentration: > 15000 nM
Compound 4: only a limit was reported (the forecaster's own chance of this, stated with the estimate: 75%); the middle value lies beyond the limit too.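

Going by these compounds alone, compound 2, compound 3 and compound 4 each carry only a limit, not a number, in this assay, and no step among them can be read. The compounds shown leave open at what concentration any of them reaches the half-maximal effect, and whether their side chains differ at all in this read-out.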